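The source may report more compounds than this note shows. Statements on the series, on what has been measured and on what is new or still open speak of the compounds shown alone.

Working notes on the cinnamoyl series in a functional assay on MCF7 cells (Homo sapiens) for cytotoxicity, read by MTT assay, with a stated time of 24 h; on this read-out lower numbers stand for stronger inhibition and higher numbers for weaker inhibition. Of the compounds shown here, three have been measured. Compound 1 `Cc1cc(O)c(C(=O)/C=C/c2ccccc2Cl)c(-c2ccc(Cl)cc2)c1C(=O)/C=C/c1ccccc1Cl` gives 30000 nM; compound 2 `Cc1cc(O)c(C(=O)/C=C/c2ccccc2)c(-c2ccc(Cl)cc2)c1C(=O)/C=C/c1ccccc1` gives 15000 nM; compound 3 `Cc1cc(O)c(C(=O)/C=C/c2ccc(Cl)cc2)c(-c2ccc(Cl)cc2)c1C(=O)/C=C/c1ccc(Cl)cc1` gives 28000 nM. All three numbers sit within the usual scatter of one another, so none of them can be set apart as more or less active than the others; the value of compound 2 lies at the low edge of this band, and both of its gaps, to compound 3 and to compound 1, stay inside the scatter.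

The next compound, compound 4 `Cc1cc(O)c(C(=O)/C=C/c2ccccc2)c(-c2ccccc2)c1C(=O)/C=C/c1ccccc1`, differs from compound 2 in one place: hydrogen in place of chloro on an aromatic carbon, read one bond further out as 4-chlorophenyl to phenyl. Going by the values given here, no measured pair in this assay shows such a change, so there is no step to lean on. With the three measured numbers lying so close together, the expectation is a step from compound 2 to compound 4 of a 1.1-fold higher number from compound 2 to compound 4 (0.05 log units; within the scatter), not beyond the scatter in either direction. Compound 4 is therefore estimated at 17000 nM, with a range from 6000 nM to 45000 nM.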

Compound 4, half-maximal inhibitory concentration: 10000 nM
Compound 4: the middle estimate sits 1.7-fold (0.23 log units) above what was measured; the measured number falls inside the stated range.
By their numbers in this assay, from the lowest: compounds 4, 2, 3 and 1 (each within the scatter of the next, the first and the last beyond it).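

In this assay the first pair differing in one place gives a 1.5-fold lower number from compound 2 to compound 4 (0.18 log units; within the scatter) for hydrogen in place of chloro on an aromatic carbon. Going from 4-chlorophenyl to phenyl at this position therefore leaves the number within the scatter, and compound 4 shows that the chloro is not required for a measurable value in this assay. No measurement bears on why the step has this size.

The compounds shown leave open whether an amine, a methoxy group or a carboxylic acid at this position would move the number beyond the scatter. Also open, on these data alone, is what a single chloro on one cinnamoyl ring does, as compound 1 and compound 3 each differ from compound 2 in more than one place.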